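A carbamate in place of an ether on the side chain

A few compounds are considered here, and "the series" means these few. Any claim that something is new, unique, unknown or untested is made for them only; others in the source may bear on it.

Compound 1 `CCOCc1c(C)nc2c(OCc3ccccc3)cccn12` is the strongest of the three measured compounds in a functional assay on the whole organism (stomach) for inhibition, with Canis familiaris (Canis lupus familiaris) as the target, at a dose of 5 mg/kg by the intravenous route (a higher number here means a stronger effect of the compound at the dose given, a lower number a weaker effect), where compound 1 gives 35%. Its two neighbours change only the group on the saturated chain carbon bound to an aromatic carbon. Compound 2 `CCSCc1c(C)nc2c(OCc3ccccc3)cccn12` carries ethylsulfanyl in place of ethoxy there, and compound 2 gives 0%, a fall of a number 35 percentage points lower from compound 1 to compound 2 (beyond the scatter). Compound 3 `COC(=O)Cc1c(C)nc2c(OCc3ccccc3)cccn12` carries methoxycarbonyl in place of ethoxy, and compound 3 gives 16%, a fall of a number 19 percentage points lower from compound 1 to compound 3 (beyond the scatter). Between those two stands a number 16 percentage points higher from compound 2 to compound 3 (beyond the scatter).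

Compound 4 `Cc1nc2c(OCc3ccccc3)cccn2c1COC(=O)N(C)C` keeps the oxygen of compound 1 but changes what sits on it: dimethylcarbamoyl in place of ethyl on an oxygen on a saturated carbon. Among the compounds with values here, no measured step alters this oxygen itself; the nearest guidance comes from the two steps away from compound 1, each of which lowered the read-out when the ethoxymethyl side chain was altered, the larger loss going with loss of the oxygen. Because a number 35 percentage points lower from compound 1 to compound 2 (beyond the scatter) went with loss of the oxygen, which compound 4 retains, a smaller loss is expected for compound 4, roughly a number 10 percentage points lower from compound 1 to compound 4 (within the scatter), while a result within the scatter of compound 1 is not excluded. The estimate for compound 4 is therefore 25%, expected to lie between 5% and 50%.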

Compound 4, a percentage reported as inhibition, in the whole organism at one dose (the size of the read-out at that dose, not a potency): 23%
The estimate for compound 4 lay 2 percentage points above the measured number, and the stated range covers the measured number.
By their numbers in this assay, from the lowest: compound 2; then compounds 3 and 4 (each within the scatter of the next); then compound 1.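

In this assay keeping the side-chain oxygen does not by itself keep the full effect: dimethylcarbamoyl in place of ethyl on that oxygen gives a number 12 percentage points lower from compound 1 to compound 4 (beyond the scatter) and leaves compound 1 the strongest of the four, so the group on the oxygen counts as well as the oxygen. Against ethylsulfanyl, the (dimethylcarbamoyl)oxy group gives a number 23 percentage points higher from compound 2 to compound 4 (beyond the scatter) and against methoxycarbonyl it gives a number 7 percentage points higher from compound 3 to compound 4 (within the scatter) so that the carbamate and the ester cannot be told apart here, though both stand clear of compound 2 on one side and compound 1 on the other. No measurement shown here accounts for these differences.

From the compounds shown here alone, whether a hydroxyl or a dimethylamino group on this saturated chain carbon, or a propyl or longer chain on the oxygen in place of ethyl, would match or pass compound 1 remains open. Going by these compounds, all four values also come from a single dose by a single route, so how these compounds would rank at other doses remains open as well.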